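Diyne alcohols: terminal vinyl taken off the side chain

The compounds below may be only part of what the source reports. "The series", "measured", "known", "first", "only" and "open" are said of these compounds alone.

Compound 2 `C=CCCCCCCCC#CC#CCO` gives 5.26 ug/mL in a functional assay on XF498 cells (Homo sapiens) for cytotoxicity (on this read-out higher numbers stand for an effect only at larger amounts of compound and lower numbers for an effect already at smaller amounts), the lowest of the two numbers recorded so far; its nearest neighbour is compound 1 `C=CCCCCCC#CC#CCO`, which gives 10.8 ug/mL in this assay. Among the measured compounds shown here, the only measured step, a 2.1-fold lower number from compound 1 to compound 2 (0.31 log units; beyond the scatter), is modest. Compound 3 `CCCCCCCC#CC#CCO` differs from compound 2 by hydrogen in place of vinyl on a saturated chain carbon, seven bonds along the chain from a triple-bonded carbon. This change undoes the chain extension of the earlier step and removes the remaining double bond as well, so a modest move in the opposite direction is expected: a 1.8-fold higher number from compound 2 to compound 3 (0.26 log units; within the scatter). For compound 3 in this assay the estimate is 9.5 ug/mL, with a range of 4.5 ug/mL to 20 ug/mL.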

Compound 3, concentration for half-maximal effect: 5.59 ug/mL
Compound 3: the middle estimate sits 1.7-fold (0.23 log units) above what was measured; the measured number falls inside the stated range.
By their numbers in this assay, from the lowest: compounds 2, 3 and 1 (each within the scatter of the next, the first and the last beyond it).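

Removing the terminal double bond costs nothing measurable in this assay: hydrogen in place of vinyl gives a 1.1-fold higher number from compound 2 to compound 3 (0.03 log units; within the scatter) and so the double bond is not required for cytotoxicity at this level. Ethyl in place of vinyl gives a 1.9-fold lower number from compound 1 to compound 3 (0.29 log units; within the scatter) and compound 3 therefore cannot be separated from either neighbour, even though those two neighbours lie beyond the scatter of each other. Nothing available explains these results.

Still open, from the compounds shown here alone, is how a longer saturated chain would read in this assay on this diyne alcohol. Equally open, going by these compounds, is the effect of an amine in place of the hydroxyl.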